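Replacing an Aromatic Amine with Fluorine on a Shared Core

The compounds below may be only part of what the source reports. "The series", "measured", "known", "first", "only" and "open" are said of these compounds alone.

Compound 1 `C/C=C/C(=O)N(Cc1ccc(OC)c(N)c1)c1cc(OC)c(OC)c(OC)c1` is the reference point of this account. In a functional assay on KYSE-450 cells (Homo sapiens) for inhibition, read by MTT assay, with a stated time of 48 h (on this read-out higher numbers stand for weaker inhibition and lower numbers for stronger inhibition), compound 1 gives 310 nM, the second highest of the three numbers in hand. Within the data shown here, compound 3 `CC/C=C/C(=O)N(Cc1ccc(OC)c(O)c1)c1cc(OC)c(OC)c(OC)c1` gives 72 nM, a lower number that stands for stronger inhibition, though compound 3 differs from compound 1 in two places and so supplies no single counted step. Compound 2 `COc1ccc(CNc2cc(OC)c(OC)c(OC)c2)cc1N` gives 2210 nM; the step of a 7.1-fold higher number from compound 1 to compound 2 (0.85 log units; beyond the scatter) arises from hydrogen in place of (prop-1-en-1-yl)carbonyl on a nitrogen on an aromatic ring, a change on the amide rather than on the aromatic ring carrying the amino group.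

Compound 4 `C/C=C/C(=O)N(Cc1ccc(OC)c(F)c1)c1cc(OC)c(OC)c(OC)c1` is the compound whose number is awaited. It differs from compound 1 as follows: fluoro in place of amino on an aromatic carbon. Among the measured compounds shown here, none of the measured steps touches this place; the one counted step concerns the acyl group, and compound 3 alters both the aromatic substituent and the chain at once. For the measured compounds named here, the data give no direct precedent, so a step within or only a little beyond the scatter is expected, with the direction open. Compound 4 is expected to give 400 nM, within a range from 150 nM to 1100 nM, which corresponds to an expected step of a 1.3-fold higher number from compound 1 to compound 4 (0.11 log units; within the scatter).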

Compound 4, half-maximal inhibitory concentration: 1400 nM
The estimate for compound 4 lay 3.5-fold (0.54 log units) below the measured number, and the stated range ends below it.
By their numbers in this assay, from the lowest: compound 3; then compound 1; then compounds 4 and 2 (each within the scatter of the next).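

In this assay, among these compounds, this aromatic carbon, ortho to a methoxy group, proves sensitive to its substituent: fluoro in place of amino gives a 4.5-fold higher number from compound 1 to compound 4 (0.65 log units; beyond the scatter), a step beyond the scatter and the first counted change at this place, where the earlier counted step concerned only the acyl group on the nitrogen. Going from 3-amino-4-methoxyphenyl to 3-fluoro-4-methoxyphenyl exchanges a group counted with a hydrogen-bond donor and acceptor for one counted with neither, and on this core the amino compound gives the lower number, which stands for stronger inhibition, though this single pair cannot show which part of the exchange matters. No measurement in hand accounts for the step.

On these data alone, it remains open how a hydroxy group would read at this place with the (prop-1-en-1-yl)carbonyl group kept, since compound 3 carries hydroxy together with a different acyl chain. Also open, as far as these compounds go, are how a chlorine atom, a methylamino group or plain hydrogen would read here, and whether the fluoro for amino step would hold on the secondary amine of compound 2.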